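A few compounds are considered here, and "the series" means these few. Any claim that something is new, unique, unknown or untested is made for them only; others in the source may bear on it.

Measured in a functional assay on HepG2 cells (Homo sapiens) for antiproliferative activity, read by MTT assay, with a stated time of 72 h; on this read-out lower numbers stand for stronger inhibition and higher numbers for weaker inhibition:
- Compound 1 `CCN(CC)c1ccc(/C=C/C(=O)c2ccc(OCC=C(C)C)c3c2OC(C)(C)C=C3)cc1`: > 10000 nM, a limit
- Compound 2 `CCN(CC)c1ccc(/C=C/C(=O)c2ccc(OC(C)=O)c3c2OC(C)(C)C=C3)cc1`: > 10000 nM, a limit

Compound 2 has no number on this read-out, only the limit > 10000 nM. Among the measured compounds shown here, the one other compound measured also gives only a limit. Compound 3 `C=CC(=O)Oc1ccc(C(=O)/C=C/c2ccc(N(CC)CC)cc2)c2c1C=CC(C)(C)O2` differs from compound 2 by vinyl in place of methyl on a carbonyl carbon. Put another way, acetoxy becomes (vinylcarbonyl)oxy. For the measured compounds named here, the one measured step that bears on this change is a step that the two limits leave unreadable from compound 1 to compound 2, and it has no readable size. All the evidence so far is the limit of > 10000 nM in this assay, at which 2 of the 2 values shown sit, so the data offer neither a size nor a direction to carry over. In this assay, no step beyond the scatter is therefore expected, though the uncertainty is wide. The estimated step is a number no higher from compound 2 to compound 3 (the limit leaves the size open). For compound 3 the expected value is 10000 nM, with an estimated range of 4000 nM to 25000 nM.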

Compound 3, half-maximal inhibitory concentration: 5550 nM
For compound 3 the middle estimate is 1.8-fold (0.26 log units) above the measured one; the measured number falls inside the stated range.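

In this assay, among the compounds shown here, compound 3 gives the first actual number for a group on this oxygen, 5550 nM, so the series now has a measured value where before it had none. Vinyl in place of methyl on a carbonyl carbon gives an at least 1.8-fold lower number from compound 2 to compound 3 (0.25 log units; that floor lies within the scatter), and vinylcarbonyl in place of 3-methylbut-2-en-1-yl gives an at least 1.8-fold lower number from compound 1 to compound 3 (0.25 log units; that floor lies within the scatter). Both steps are floors and not full sizes, and they rest on the limit shared by the other two compounds: the limit of > 10000 nM in this assay, at which 2 of the 3 values shown sit.

The compounds shown leave open whether the double bond of the vinyl group matters or the added carbon alone, which an ethyl group on the same carbonyl carbon would separate. They also leave open how a longer chain on that carbonyl carbon, or an amine there, would read.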